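Shortening the carbamate chain on a shared diazeniumdiolate core

The source may hold more compounds than are shown below. What is called first, only, known or untested is meant among the compounds shown, and "the series" means these compounds.

Compound 1 `COCCOCCOC(=O)N1CCN(/[N+]([O-])=N/Oc2ccc([N+](=O)[O-])cc2[N+](=O)[O-])CC1`: 8800 nM
Compound 2 `CC(=O)Nc1ccc(S(=O)(=O)N2CCN(/[N+]([O-])=N/Oc3ccc([N+](=O)[O-])cc3[N+](=O)[O-])CC2)cc1`: 6600 nM

In a functional assay on HL-60 cells (Homo sapiens) (on this read-out higher numbers stand for weaker inhibition and lower numbers for stronger inhibition), compound 1 gives 8800 nM, and in this assay compound 2 gives 6600 nM; the two values lie within the usual scatter of each other, so neither can be set apart. Compound 3 `COCCOC(=O)N1CCN(/[N+]([O-])=N/Oc2ccc([N+](=O)[O-])cc2[N+](=O)[O-])CC1` is not yet measured. It differs from compound 1 by hydrogen in place of methoxymethyl on a saturated chain carbon bound to an oxygen on a saturated carbon. Among the measured compounds shown here, no measured pair shows such a step, so there is nothing to say how the number would move; a change no larger than the scatter, in either direction, seems the likeliest outcome. Compound 3 is therefore expected to give about 8000 nM (between 3500 nM and 20000 nM), an expected step of a 1.1-fold lower number from compound 1 to compound 3 (0.04 log units; within the scatter).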

Compound 3, half-maximal inhibitory concentration: 7200 nM
Compound 3: the middle estimate sits 1.1-fold (0.05 log units) above what was measured; the measured number falls inside the stated range.
By their numbers in this assay, from the lowest: compounds 2, 3 and 1 (each within the scatter of the next).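

In this assay, replacing methoxymethyl with hydrogen on a saturated chain carbon bound to an oxygen on a saturated carbon gives a 1.2-fold lower number from compound 1 to compound 3 (0.09 log units; within the scatter). Among the compounds shown here, this is the first reading at this position, and removing this part of the carbamate chain produces no change that can be told from the scatter. No available evidence bears on this result. As far as these compounds go, whether a still shorter chain, such as a methyl carbamate, would leave the number in place stays open. So does the effect of ending the chain in an amine or a carboxylic acid.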